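The compounds below may be only part of what the source reports. "The series", "measured", "known", "first", "only" and "open" are said of these compounds alone.

Among the measured compounds shown here, compound 3 (`CCCCCC(C#CC(=O)OC)O/C=C/C(=O)OC`) gives 1900 nM in a functional assay on HBL-100 cells (Homo sapiens) for antiproliferative activity, read by sulforhodamine B assay, with a stated time of 48 h (on this read-out higher numbers stand for weaker inhibition of growth and lower numbers for stronger inhibition of growth), and compound 2 (`CCOC(=O)C#CC(O/C=C/C(=O)OCC)C(C)C`) gives 3000 nM there, so the only two numeric values lie within the scatter of each other. Compound 3 therefore shares its level with compound 2. Compound 1 (`CCCCCCC(C#CC(=O)O)O/C=C/C(=O)OC`) returns only a limit, > 100000 nM in this assay, and not a number.

The next step leads to compound 4 (`CCCC(C#CC(=O)OC)O/C=C/C(=O)OC`), with hydrogen in place of ethyl on a saturated chain carbon, four bonds along the chain from an oxygen on an unsaturated carbon and a triple-bonded carbon as the counted change: hydrogen in place of ethyl on a saturated chain carbon, four bonds along the chain from an oxygen on an unsaturated carbon and a triple-bonded carbon. Read one bond further out, this is pentyl to propyl.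

For the measured compounds named here, no measured pair isolates this change, so the expectation in this assay rests on little. Compound 3 at 1900 nM and compound 2 at 3000 nM sit close together, which offers no ground for expecting a large move. A small shift towards a higher number is expected, possibly none beyond the scatter. The estimated step of a 1.5-fold higher number from compound 3 to compound 4 (0.17 log units; within the scatter) is accordingly small. For compound 4 the expected value in this assay is 2800 nM within an estimated range of 900 nM to 9000 nM for this measurement.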

Compound 4, concentration for 50% growth inhibition: 270 nM
For compound 4 the middle estimate is 10-fold (1.02 log units) above the measured one; measured number outside the range, below it.
By their numbers in this assay, from the lowest: compound 4; then compounds 3 and 2 (each within the scatter of the next). At a limit, above all of these: compound 1.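

Cutting the chain from pentyl to propyl at this saturated chain carbon gives a 7.0-fold lower number from compound 3 to compound 4 (0.85 log units; beyond the scatter) in this assay, and this is the first step in the series that isolates a single change. Among the compounds shown here, it shows that the length of this chain alone can move the read-out beyond the scatter, which the earlier compounds, differing in more than one place, could not show. The shorter chain goes with stronger inhibition of growth in this one pair only, and no measurement shown here accounts for the step.

On these data alone, with only pentyl and propyl compared on an otherwise identical structure, it remains open whether the response changes steadily with chain length or turns at some point, and a butyl chain or an ethyl chain in the same place would help to separate these readings, as would an amine at the end of the chain. Compound 1 gives only a limit, > 100000 nM, so it adds no number to this comparison.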